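The source may report more compounds than this note shows. Statements on the series, on what has been measured and on what is new or still open speak of the compounds shown alone.

Measured so far in an assay on HEK293 cells for displacement of a labelled ligand from 5-hydroxytryptamine receptor 7 (Rattus norvegicus), with a stated time of 60 min; a lower number here means a stronger inhibitor, a higher number a weaker inhibitor:
- compound 1 `Clc1ccc(-c2cn(Cc3ccccc3)c3c2CNCC3)cc1Cl`: compound 1 gives 4470 nM
- compound 2 `Clc1ccc(-c2cn(Cc3ccccc3)c3c2CNCC3)c(Cl)c1`: compound 2 gives 2070 nM
- compound 3 `O=[N+]([O-])c1ccc(-c2cn(Cc3ccccc3)c3c2CNCC3)cc1`: compound 3 gives 450 nM

Compound 2 stands second highest of the three numbers. Among the measured compounds shown here, its nearest neighbour is compound 1, and the only single-point step in the set, a 2.2-fold lower number from compound 1 to compound 2 (0.33 log units; beyond the scatter), is modest in size though beyond the scatter. The furthest number is that of compound 3, which carries a nitrophenyl group in place of a chlorophenyl group and shows the lowest number of the three.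

Compound 4 `Clc1cccc(-c2cn(Cc3ccccc3)c3c2CNCC3)c1` differs from compound 2 in one place: 3-chlorophenyl in place of 2,4-dichlorophenyl on an aromatic carbon. For the measured compounds named here, only the step from compound 1 to compound 2 bears on this change, since it concerns the same chlorophenyl group, and it was modest. Going by the values given here, no measured pair removes a chlorine from the phenyl ring. A step of at most modest size is therefore expected for compound 4 in this assay, with the direction uncertain; the expected step is a 1.0-fold lower number from compound 2 to compound 4 (0.01 log units; within the scatter). Compound 4 is estimated at 2000 nM, in the range 700 nM to 6000 nM.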

Compound 4, inhibition constant: 10000 nM
Estimate against measurement, compound 4: 5.0-fold (0.70 log units) below; the measured number lies above the stated range.
By their numbers in this assay, from the lowest: compound 3; then compound 2; then compound 1; then compound 4.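

In this assay, the 3-chlorophenyl group of compound 4 gives a higher number than either dichlorophenyl group, and both steps run the same way (a 4.8-fold higher number from compound 2 to compound 4 (0.68 log units; beyond the scatter); a 2.2-fold higher number from compound 1 to compound 4 (0.35 log units; beyond the scatter)). Among the compounds shown here, the second step is the first direct reading of a chlorine removed from this phenyl ring: hydrogen in place of chloro raises the number from the 3,4-dichlorophenyl level. At this aromatic carbon, the second chlorine therefore goes with a lower number in both pairs, and the larger step comes from the 2,4-dichlorophenyl compound. Nothing at hand accounts for the direction or size of these steps. Still open, from the compounds shown here alone, is how an unsubstituted phenyl group would read, and whether a methoxy, amino or nitrile group on this ring would give a number as low as that of compound 3 (450 nM).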